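A few compounds are considered here, and "the series" means these few. Any claim that something is new, unique, unknown or untested is made for them only; others in the source may bear on it.

Measured so far:
- compound 1 `COc1ccc(-c2ccc3c(NCCCNCc4cccc(OC)c4O)ccnc3c2)cc1`: 237 10^-6 cm/s
- compound 2 `COc1ccc(F)cc1CNCCCNc1ccnc2cc(Oc3ccc(F)cc3)ccc12`: 317 10^-6 cm/s

Notes on the series. In an ADME assay for permeability, using PAMPA, with a stated time of 30 min, at pH 7.4 (a lower number here means that the compound crosses the layer more slowly, a higher number that the compound crosses the layer faster), compound 1 gives 237 10^-6 cm/s, and in this assay compound 2 gives 317 10^-6 cm/s. Compound 1 has the lower of the two numbers, but the gap to compound 2 is within the scatter, so nothing separates them on these two readings. For the measured compounds named here, both sit at the fast end of what this assay reports, and no step between measured compounds is available to show how a change on the shared core moves the number.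

Compound 3 `COc1cccc(CNCCCNc2ccnc3cc(Cc4cc(C)cc(C)c4)ccc23)c1O` is not yet measured. Against compound 1 it differs at one place:

3,5-dimethylbenzyl in place of 4-methoxyphenyl on an aromatic carbon

The leaving group carries the one hydrogen-bond acceptor of the exchanged part; the entering group carries none. Going by the values given here, with no measured step to lean on, the expectation for this assay rests only on compound 1 at 237 10^-6 cm/s and compound 2 at 317 10^-6 cm/s, both already high. The step of a 1.1-fold higher number from compound 1 to compound 3 (0.06 log units; within the scatter) is expected to stay within the scatter, with no direction claimed. For compound 3 the estimate is 270 10^-6 cm/s, between 140 10^-6 cm/s and 480 10^-6 cm/s.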

Compound 3, apparent permeability: 23 10^-6 cm/s
Beside the measured number, compound 3's estimate is 12-fold (1.07 log units) above it; measured number outside the range, below it.
By their numbers in this assay, from the lowest: compound 3; then compounds 1 and 2 (each within the scatter of the next).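

In this assay, 3,5-dimethylbenzyl in place of 4-methoxyphenyl on an aromatic carbon of the shared core gives a 10-fold lower number from compound 1 to compound 3 (1.01 log units; beyond the scatter) and so shows that this position is not indifferent: one exchange here moves the number well beyond the scatter, which the two earlier readings could not reveal. The exchange alters several features at once, replacing a group that contains oxygen with one of carbon only and also changing the substitution and the attachment of the aromatic ring, so the step belongs to the whole change and not to any one of these features. Nothing measured on these compounds accounts for the size of this step.

The compounds shown leave open which feature of the exchange carries the step, and 4-methoxybenzyl or 3,5-dimethylphenyl at this carbon would separate the attachment from the substituents on the ring. Also open, going by these compounds, is how the number would respond here to a group of a different kind, such as a morpholine or a carboxylic acid.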